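Methylating a phenol in a weak thiosulfate sulfurtransferase series

A few compounds are considered here, and "the series" means these few. Any claim that something is new, unique, unknown or untested is made for them only; others in the source may bear on it.

Of the compounds shown here, three have been tested in an assay on isolated protein for inhibition of thiosulfate sulfurtransferase (Homo sapiens), with a stated time of 60 min, in the absence of a further agent; a lower number here means a stronger inhibitor, a higher number a weaker inhibitor. Compound 1 `COc1c(Br)cccc1C(=O)Nc1ccc(Sc2nc3ccccc3s2)cc1` gives only a limit of the assay, > 100000 nM. Compound 2 `O=C(Nc1ccc(Sc2nc3ccccc3s2)cc1)c1cccc(Br)c1O` likewise stops at the limit, > 100000 nM. Compound 3 `O=C(Nc1cccc(Cl)c1)c1cccc(Br)c1O` also reaches only the limit, > 100000 nM. The change from compound 2 to compound 1 is methyl in place of hydrogen on an oxygen on an aromatic ring, and the step that the two limits leave unreadable from compound 2 to compound 1 cannot be read because of the limit of > 100000 nM in this assay, at which 3 of the 3 values shown sit. Compound 4 `COc1c(Br)cccc1C(=O)Nc1cccc(Cl)c1` carries the same change from compound 3, (methyl in place of hydrogen on an oxygen on an aromatic ring). The difference between the core of compound 3 and the core of compound 2 is not broken down here. Since all three measured compounds sit at the limit, the step from compound 3 to compound 4 in this assay is expected to be unreadable as well, about a step that the limit leaves unreadable from compound 3 to compound 4. Compound 4 is therefore expected to give roughly 200000 nM, most likely again only a limit.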

Compound 4, half-maximal inhibitory concentration: > 100000 nM
Compound 4: a limit, no number; the forecaster's own chance of this, stated with the estimate: 85%; the middle value does not contradict the limit.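

No step can be read from compound 3 to compound 4, because both stop at the same limit: the limit of > 100000 nM in this assay, at which 4 of the 4 values shown sit.

The compounds shown leave open whether hydroxy to methoxy changes inhibition at all, and how strongly any of the four compounds truly inhibits.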